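From methyl to 4-phenylpiperazin-1-yl on the chain

The source may report more compounds than this note shows. Statements on the series, on what has been measured and on what is new or still open speak of the compounds shown alone.

In a functional assay on the whole organism for antagonist activity, with Mus musculus as the target (on this read-out lower numbers stand for an effect already at smaller amounts and higher numbers for an effect only at larger amounts of compound), compound 1 (`CN(C(=O)CNC(=O)CN1CCCCC1)c1ccc(Cl)cc1C(=O)c1ccccc1Cl`) stands at 7.5 mg/kg while compound 2 (`CCC(=O)NCC(=O)N(C)c1ccc(Cl)cc1C(=O)c1ccccc1Cl`) stands at 1.4 mg/kg and so holds the lower of the two numbers. Among the compounds with values here, the only measured step shows a 5.4-fold lower number from compound 1 to compound 2 (0.73 log units; beyond the scatter) when methyl takes the place of piperidin-1-yl on a saturated chain carbon bound to a carbonyl carbon. Compound 3 (`CN(C(=O)CNC(=O)CN1CCN(c2ccccc2)CC1)c1ccc(Cl)cc1C(=O)c1ccccc1Cl`) differs from compound 2 by 4-phenylpiperazin-1-yl in place of methyl on a saturated chain carbon bound to a carbonyl carbon and so has 4-phenylpiperazin-1-yl in place of methyl at that same carbon. Within the data shown here, this runs against the direction of the measured step, which is the one piece of evidence that bears on the change. On the strength of compound 1 at 7.5 mg/kg a move to a higher number of similar size is expected in this assay for compound 3. Among the measured compounds shown here, no measured compound carries the added aromatic ring, so the uncertainty is wide. The expected change is a 5.0-fold higher number from compound 2 to compound 3 (0.70 log units; beyond the scatter) in this estimate. The estimate for compound 3 is 7 mg/kg (expected range 2.5 mg/kg to 25 mg/kg).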

Compound 3, dose for half-maximal effect: 75 mg/kg
For compound 3 the middle estimate is 11-fold (1.03 log units) below the measured one, and the stated range ends below it.
By their numbers in this assay, from the lowest: compound 2; then compound 1; then compound 3.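

In this assay, within the data shown here, the saturated chain carbon bound to a carbonyl carbon proves far less forgiving than the first pair of compounds suggested: 4-phenylpiperazin-1-yl in place of methyl gives a 54-fold higher number from compound 2 to compound 3 (1.73 log units; beyond the scatter), a large step that goes well past what piperidin-1-yl had cost at the same carbon. The comparison between the two ring-bearing groups also shows that a saturated ring at this carbon does not set a fixed level in this assay, since 4-phenylpiperazin-1-yl in place of piperidin-1-yl still gives a 10-fold higher number from compound 1 to compound 3 (1.00 log units; beyond the scatter), so what the ring carries matters to the read-out. Nothing available here accounts for either step.

The compounds shown leave open whether the higher number goes with the piperazine ring itself or with the phenyl ring on it, a question that a plain piperazin-1-yl or a 4-methylpiperazin-1-yl at this carbon would separate. Also open, on these data alone, is how an open-chain amine such as dimethylamino would compare with methyl and with the two ring-bearing groups at the same place.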